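The source may report more compounds than this note shows. Statements on the series, on what has been measured and on what is new or still open speak of the compounds shown alone.

In a functional assay on HeLa cells (Homo sapiens) for cytotoxicity, read by MTT assay (a lower number here means a stronger inhibitor, a higher number a weaker inhibitor), compound 1 `CCCCC(O)CC(=O)O[C@H](CC=C(C)C)C1=CC(=O)c2c(O)ccc(O)c2C1=O` gives 72200 nM, and compound 2 `CC(=O)OC(C)CO[C@H](CC=C(C)C)C1=CC(=O)c2c(O)ccc(O)c2C1=O` gives 40100 nM. Of the two numbers shown, that of compound 2 is the lowest. The step behind that order, however, is small: a 1.8-fold lower number from compound 1 to compound 2 (0.26 log units; within the scatter) lies within the scatter, so the two compounds are not truly separated.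

Compound 3 `CCCCC(C)(O)CC(=O)O[C@H](CC=C(C)C)C1=CC(=O)c2c(O)ccc(O)c2C1=O` has not yet been measured. It differs from compound 2 in one place: (2-hydroxy-2-methylhexyl)carbonyl in place of 2-acetoxypropyl on an oxygen on a saturated carbon. For the measured compounds named here, the only measured step that bears on this change is the one run the other way, a 1.8-fold lower number from compound 1 to compound 2 (0.26 log units; within the scatter), which exchanged (2-hydroxyhexyl)carbonyl for 2-acetoxypropyl and stayed within the scatter. The entering (2-hydroxy-2-methylhexyl)carbonyl is close to the (2-hydroxyhexyl)carbonyl of compound 1. No step beyond the scatter is therefore expected in this assay. Compound 3 is expected to give about 70000 nM, between 30000 nM and 160000 nM, an estimated step of a 1.7-fold higher number from compound 2 to compound 3 (0.24 log units; within the scatter).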

Compound 3, half-maximal inhibitory concentration: 60600 nM
The estimate for compound 3 lay 1.2-fold (0.06 log units) above the measured number; the range from low to high includes it.
By their numbers in this assay, from the lowest: compounds 2, 3 and 1 (each within the scatter of the next).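

In this assay, the exchange of 2-acetoxypropyl, with 7 heavy atoms, for (2-hydroxy-2-methylhexyl)carbonyl, with 10 heavy atoms and 1 hydrogen-bond donor, gives a 1.5-fold higher number from compound 2 to compound 3 (0.18 log units; within the scatter) and does not separate the two compounds. For the compounds shown here, the result also gives the first reading of a single methyl in place of hydrogen on the saturated chain carbon, where a 1.2-fold lower number from compound 1 to compound 3 (0.08 log units; within the scatter) shows that this small addition leaves the number within the scatter as well. All three groups on this oxygen therefore give numbers that cannot be told apart in this assay, and nothing measured here offers an explanation for that.

The compounds shown leave open whether any group on this oxygen can move the number beyond the scatter. An amine or a carboxylic acid at the end of the chain, or a much longer chain, would test this.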